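This account rests on a few compounds, and the source may have more. Where it says the series, first, only, none or still open, it means among the compounds named here.

Among the measured compounds shown here, the series shares one scaffold: a tetradecyl amide of a threonine-like unit whose amine carries an acyl group, and the three measured members differ only in that acyl group. Compound 1 `CCCCCCCCCCCCCCNC(=O)[C@@H](NC(=O)c1cc2ccccc2o1)[C@@H](C)O` gives 14200 nM in a functional assay on SiHa cells (Homo sapiens) for cytotoxicity, read by MTT assay, with a stated time of 48 h; a lower number here means a stronger inhibitor, a higher number a weaker inhibitor. Compound 2 `CCCCCCCCCCCCCCNC(=O)[C@@H](NC(=O)c1cc2ccccc2[nH]1)[C@@H](C)O` gives 14200 nM in this assay, and the step of no change at the digits printed from compound 1 to compound 2 (within the scatter) shows that this exchange leaves the number where it was. Compound 3 `CCCCCCCCCCCCCCNC(=O)[C@@H](NC(=O)/C=C/c1ccccc1)[C@@H](C)O` gives 35800 nM in this assay, the highest of the three numbers, separated from the other two by modest steps: a 2.5-fold higher number from compound 1 to compound 3 (0.40 log units; beyond the scatter) and a 2.5-fold higher number from compound 2 to compound 3 (0.40 log units; beyond the scatter).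

Compound 4 `CCCCCCCCCCCCCCNC(=O)[C@@H](NS(=O)(=O)c1ccc(C)cc1)[C@@H](C)O` is not yet measured. It differs from compound 3 at the amine nitrogen, where ((4-methylphenyl)sulfonyl in place of (2-phenylethenyl)carbonyl on an amine nitrogen). Both measured steps that reach compound 3 concern only the aromatic part attached to the carbonyl; none exchanges the carbonyl itself for a sulfonyl, so the measured steps bear on this change only loosely. They do show that the three acyl variants stay within a narrow band of numbers, and the change to compound 4 is of comparable scope at the same position. Compound 4 is therefore expected to sit near compound 3, with the step of a 1.4-fold lower number from compound 3 to compound 4 (0.16 log units; within the scatter) estimated as small, and its estimate in this assay is 25000 nM, within a range from 8000 nM to 80000 nM.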

Compound 4, half-maximal inhibitory concentration: 19200 nM
Estimate against measurement, compound 4: 1.3-fold (0.11 log units) above, and the stated range covers the measured number.
By their numbers in this assay, from the lowest: compounds 1, 2, 4 and 3 (each within the scatter of the next, the first and the last beyond it).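

In this assay, among the compounds shown here, the exchange at the amine nitrogen reaches the linking group itself for the first time, replacing the carbonyl with a sulfonyl, and it gives a 1.9-fold lower number from compound 3 to compound 4 (0.27 log units; within the scatter) when set against the (2-phenylethenyl)carbonyl group. The same exchange gives a 1.4-fold higher number from compound 2 to compound 4 (0.13 log units; within the scatter) against the (1H-indol-2-yl)carbonyl group and a 1.4-fold higher number from compound 1 to compound 4 (0.13 log units; within the scatter) against the (1-benzofuran-2-yl)carbonyl group, so the (4-methylphenyl)sulfonyl compound cannot be separated from any of the three carbonyl compounds, even though compound 3 stands beyond the scatter from compound 1 and compound 2. At this position, therefore, a sulfonyl link can stand in place of a carbonyl link without a step beyond the scatter, but no evidence is available to explain this result. 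

The compounds shown leave open how this nitrogen behaves with a free amine, or with a methanesulfonyl group that carries no aromatic ring. They also leave open whether the narrow band of numbers would hold if a carboxylic acid were placed on the aromatic ring of the sulfonyl group, or if the tetradecyl chain were replaced by a shorter chain.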